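A heptyl chain gives way to a ring-bearing group

The compounds below may be only part of what the source reports. "The series", "measured", "known", "first", "only" and "open" are said of these compounds alone.

Going by the values given here, compound 2 `CCCCCCCCc1cn(Cc2cc(=O)oc3cc(O)ccc23)nn1` is the only compound here with a measured number: in a functional assay on CFPAC-1 cells (Homo sapiens) for inhibition, read by MTT assay, with a stated time of 72 h (a lower number here means a stronger inhibitor, a higher number a weaker inhibitor), compound 2 gives 62700 nM. Compound 1 `O=c1cc(Cn2cc(C3CC3)nn2)c2ccc(O)cc2o1` is reported only as a limit in this assay, namely > 100000 nM. Among the compounds with values here, the one measured step, an at least 1.5-fold lower number from compound 1 to compound 2 (0.20 log units; that floor lies within the scatter), therefore rests on a limit of > 100000 nM in this assay, at which 1 of the 2 values shown sits, and sets only a floor. Compound 3 `O=c1cc(Cn2cc(CSC(=S)N3CCNCC3)nn2)c2ccc(O)cc2o1` differs from compound 2 by a group of 9 heavy atoms (5 carbon, 2 nitrogen, 2 sulfur; one six-membered non-aromatic ring with 2 hetero atoms) in place of a group of 7 heavy atoms (7 carbon; no ring), on a saturated chain carbon bound to an aromatic carbon, a change at the same place as the measured step but of a different kind, so that step gives only weak guidance. Both measured values sit at weak inhibition, and no shown step points strongly in either direction, so the expected step of a 1.0-fold lower number from compound 2 to compound 3 (0.02 log units; within the scatter) is small. Compound 3 is estimated at 60000 nM in this assay, within a range from 15000 nM to 200000 nM.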

Compound 3, half-maximal inhibitory concentration: > 100000 nM
Compound 3 gave a limit, no number; the forecaster's own chance of this, stated with the estimate: 35%; middle value at least 1.6-fold (0.22 log units) from the limit.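

Putting the ring-bearing group in place of the heptyl, on a saturated chain carbon bound to an aromatic carbon, adds a hydrogen-bond donor and hydrogen-bond acceptors that the chain lacks, and in this assay it gives an at least 1.5-fold higher number from compound 2 to compound 3 (0.20 log units; that floor lies within the scatter). Compound 3 yields only a limit, not a number: > 100000 nM. This exchange of a plain carbon chain for a ring-bearing group therefore gives no second measured number, and it sets only a floor on the step, so it cannot show a real loss or gain: the limit of > 100000 nM in this assay, at which 2 of the 3 values shown sit.

On these data alone, how far compound 3 truly lies from compound 2 stays unknown. The compounds shown also leave open whether a longer chain, such as decyl, or a simple amine or a carboxylic acid at this place would give a measured number.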